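Dropping the Hydroxy Group: From Compound 3 to Compound 4

This account rests on a few compounds, and the source may have more. Where it says the series, first, only, none or still open, it means among the compounds named here.

Three compounds have so far been tested in a functional assay on MCF7 cells (Homo sapiens) for antiproliferative activity, read by sulforhodamine B assay, with a stated time of 72 h, tested at 30 uM; on this read-out higher numbers stand for a weaker effect at the one concentration tested and lower numbers for a stronger effect:
compound 1 `COc1cc(Br)cc(/C=C/C(=O)c2ccc(C)cc2)c1O` gives 61.5%
compound 2 `O=C(/C=C/c1cc(Br)ccc1O)c1ccc(Br)cc1` gives 28.3%
compound 3 `Cc1ccc(C(=O)/C=C/c2cc(Br)ccc2O)cc1` gives 31.8%

Compound 3 stands second highest of these three numbers, within the scatter of compound 2 and clearly apart from compound 1: a number 3.5 percentage points higher from compound 2 to compound 3 (within the scatter); a number 29.7 percentage points lower from compound 1 to compound 3 (beyond the scatter).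

Compound 4 `Cc1ccc(C(=O)/C=C/c2cccc(Br)c2)cc1` differs from compound 3 in one place: hydrogen in place of hydroxy on an aromatic carbon. Among the measured compounds shown here, neither measured step removes a hydroxy, so no measured step bears directly on this change; the only guidance is that a single change on this core has already moved the number both within and beyond the scatter. The expected step in this assay is therefore small to modest, a number 8.2 percentage points higher from compound 3 to compound 4 (within the scatter), with a wide uncertainty. Compound 4 is expected to give about 40%, in the range 20% to 65%.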

Compound 4, a percentage reported as activity, at one concentration (the size of the read-out at that concentration, not a potency): 34%
The estimate for compound 4 lay 6 percentage points above the measured number; low and high end bracket the measured number.
By their numbers in this assay, from the lowest: compounds 2, 3 and 4 (each within the scatter of the next); then compound 1.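

In this assay the step at this position is a number 2.2 percentage points higher from compound 3 to compound 4 (within the scatter) and so shows that, on this core, the hydroxy ortho to a large group and para to a bromo group can give way to hydrogen without a change beyond the scatter. Another single change, hydrogen in place of methoxy, gave a number 29.7 percentage points lower from compound 1 to compound 3 (beyond the scatter) by contrast. On these data alone, whether an amine or a carboxylic acid on this same aromatic carbon would keep the number in this range remains open. Nothing available gives a reason for this result.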